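This account rests on a few compounds, and the source may have more. Where it says the series, first, only, none or still open, it means among the compounds named here.

Compound 1 `CCC(CC)c1ccc2c(NCCCNCc3cc(F)ccc3OC)ccnc2c1`: 4200 nM
Compound 2 `CN(C)c1cccc(Oc2ccc3c(NCCCNCc4ccco4)ccnc3c2)c1`: 14500 nM
Compound 3 `COc1ccc(F)cc1CNCCCNc1ccnc2cc(Oc3cccc(N(C)C)c3)ccc12`: 14500 nM

In a physicochemical assay for solubility, with a stated time of 18 h, at pH 7.4 (on this read-out higher numbers stand for higher solubility and lower numbers for lower solubility), compound 2 stands level with compound 3 at the digits given, and together they hold the highest number of the three; compound 1 sits furthest from it. The step of a 3.5-fold higher number from compound 1 to compound 3 (0.54 log units; beyond the scatter) went with 3-(dimethylamino)phenoxy in place of pentan-3-yl on an aromatic carbon, whereas no change at the digits printed from compound 2 to compound 3 (within the scatter) went with 5-fluoro-2-methoxyphenyl in place of furan-2-yl on a saturated chain carbon bound to an amine nitrogen. Compound 4 `Clc1ccc(Oc2ccc3c(NCCCNCc4ccco4)ccnc3c2)cc1` differs from compound 2 by 4-chlorophenyl in place of 3-(dimethylamino)phenyl on an oxygen on an aromatic ring. Within the data shown here, no measured step exchanges one group for another on that oxygen, so no step bears directly on it. Compound 4 is therefore expected to land near compound 2, at an estimated 8000 nM (range 2500 nM to 20000 nM), a step of a 1.8-fold lower number from compound 2 to compound 4 (0.26 log units; within the scatter) that is uncertain in direction.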

Compound 4, solubility: 14500 nM
Compound 4: middle estimate off by 1.8-fold (0.26 log units), on the low side; measured number inside the range.
By their numbers in this assay, from the lowest: compound 1; then compounds 2, 3 and 4 (each within the scatter of the next).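

In this assay, among these compounds, the first measured exchange on this oxygen, 4-chlorophenyl in place of 3-(dimethylamino)phenyl, gives no change at the digits printed from compound 2 to compound 4 (within the scatter). With the furan-2-yl group held constant, a number at this level therefore does not depend on the dimethylamino-bearing group at this place, and a chlorine-bearing ring without a hydrogen-bond acceptor serves equally here. No measurement offered here explains this result.

From the compounds shown here alone, whether 4-chlorophenyl gives the same number alongside 5-fluoro-2-methoxyphenyl remains open. So does the outcome with a carboxylic acid or a morpholine on the ring at this oxygen.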